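Swapping Chloro for Nitro on a Shared Core

This account rests on a few compounds, and the source may have more. Where it says the series, first, only, none or still open, it means among the compounds named here.

Of the compounds shown here, three built on one shared core have been tested in a functional assay on PC-3 cells (Homo sapiens) for antiproliferative activity, read by MTT assay, with a stated time of 48 h; a lower number here means a stronger inhibitor, a higher number a weaker inhibitor. Among the compounds with values here, compound 1 `O=C(Nc1cc(Sc2ncn[nH]2)c(O)c2ccccc12)c1ccc(Cl)cc1` gives 5520 nM, the only plain number among them. Compound 2 `O=C(Nc1cc(Sc2ncnc3nc[nH]c23)c(O)c2ccccc12)c1ccc([N+](=O)[O-])cc1` returns only a limit of the assay, > 100000 nM. Compound 3 `O=C(/C=C/c1ccc(Cl)cc1)Nc1cc(Sc2ncn[nH]2)c(O)c2ccccc12` likewise returns only a limit, > 100000 nM. Within the data shown here, the one step that can be read is an at least 18-fold higher number from compound 1 to compound 3 (1.25 log units; beyond the scatter), so compound 1 stands as the single compound with a definite value and is the starting point here.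

Compound 4 `O=C(Nc1cc(Sc2ncn[nH]2)c(O)c2ccccc12)c1ccc([N+](=O)[O-])cc1` is made from compound 1 by one change: nitro in place of chloro on an aromatic carbon. Among the measured compounds shown here, no measured step covers this exact change; the step from compound 1 to compound 3 alters a different part of the molecule, and compound 2 differs from compound 1 in two places at once, so its limit cannot be read as the effect of nitro alone. What the data do show is the limit of > 100000 nM in this assay, at which 2 of the 3 values shown sit, and that both changes made to compound 1 so far landed there. Compound 4 is therefore expected to give roughly 30000 nM, somewhere between 6000 nM and 150000 nM. The expected step is a 5.4-fold higher number from compound 1 to compound 4 (0.74 log units; beyond the scatter), a loss of potency.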

Compound 4, half-maximal inhibitory concentration: 53500 nM
Estimate against measurement, compound 4: 1.8-fold (0.25 log units) below; the measured number falls inside the stated range.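

In this assay, within the data shown here, nitro in place of chloro on an aromatic carbon, para to a large group, gives a 9.7-fold higher number from compound 1 to compound 4 (0.99 log units; beyond the scatter), a modest step and the first measured change at this position, and it shows that the group here affects the read-out. Even so, compound 4 still gives a plain number, whereas compound 2 and compound 3 stop at a limit of the assay: the limit of > 100000 nM in this assay, at which 2 of the 4 values shown sit. Measured against those limits, the data give an at least 1.8-fold lower number from compound 3 to compound 4 (0.27 log units; that floor lies within the scatter), and they also give an at least 1.8-fold lower number from compound 2 to compound 4 (0.27 log units; that floor lies within the scatter). Both are floors set by limits of the assay, so neither fixes the size of the step.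

With only chloro and nitro shown at this position, it stays open how an amine, a methoxy group or a plain hydrogen would behave there. Also open, going by these compounds, is whether the same swap would shift the number for compounds carrying the larger group on sulfur found in compound 2.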